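A few compounds are considered here, and "the series" means these few. Any claim that something is new, unique, unknown or untested is made for them only; others in the source may bear on it.

In a functional assay on SH-SY5Y cells (Homo sapiens) for antiproliferative activity, read by MTT assay, with a stated time of 72 h (on this read-out lower numbers stand for stronger inhibition and higher numbers for weaker inhibition), compound 1 `COc1cc2c(Nc3ccc(C#N)cc3)ncnc2cc1OCCCN1CCCC1` gives 8080 nM, compound 2 `COc1cc2c(Nc3ccc(C#N)cc3)ncnc2cc1OCCCN1CCN(c2ccncc2)CC1` gives 31600 nM and compound 3 `COc1cc2c(Nc3cccc(C#N)c3)ncnc2cc1OCCCN1CCCC1` gives 10600 nM. Compound 3 therefore lies within the usual scatter of compound 1, and its number is clearly lower than that of compound 2. Compound 4 `COc1cc2c(Nc3cccc(C#N)c3)ncnc2cc1OCCCN1CCN(C)CC1` changes compound 3 in one place: 4-methylpiperazin-1-yl in place of pyrrolidin-1-yl on a saturated chain carbon, three bonds along the chain from an oxygen on an aromatic ring. The closest guide is a 3.9-fold higher number from compound 1 to compound 2 (0.59 log units; beyond the scatter), where 4-(pyridin-4-yl)piperazin-1-yl replaced pyrrolidin-1-yl. That is a related swap, not the same one. The other measured step, a 1.3-fold higher number from compound 1 to compound 3 (0.12 log units; within the scatter), exchanged 4-cyanophenyl for 3-cyanophenyl and stayed within the scatter. A rise of smaller size is expected in this assay, perhaps not beyond the scatter. The expected step is a 1.5-fold higher number from compound 3 to compound 4 (0.18 log units; within the scatter). For compound 4 the estimate is 16000 nM, with an expected range of 7000 nM to 35000 nM.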

Compound 4, half-maximal inhibitory concentration: 6890 nM
Compound 4: middle estimate off by 2.3-fold (0.37 log units), on the high side; measured number outside the range, below it.
By their numbers in this assay, from the lowest: compounds 4, 1 and 3 (each within the scatter of the next); then compound 2.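

In this assay, the change gives a 1.5-fold lower number from compound 3 to compound 4 (0.19 log units; within the scatter), so this chain end accepts 4-methylpiperazin-1-yl without leaving the scatter around the pyrrolidin-1-yl compound. A piperazine ring at this position therefore does not always bring a rise like a 3.9-fold higher number from compound 1 to compound 2 (0.59 log units; beyond the scatter), seen with 4-(pyridin-4-yl)piperazin-1-yl on the 4-cyanophenyl series. Nothing available here explains the difference between these two steps. Still open, from the compounds shown here alone, is whether morpholin-4-yl or a longer chain would also stay within the scatter, and how 4-methylpiperazin-1-yl behaves alongside 4-cyanophenyl.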